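A few compounds are considered here, and "the series" means these few. Any claim that something is new, unique, unknown or untested is made for them only; others in the source may bear on it.

Compound 1 `CC(C)(C)c1ccc(NC(=O)NCCCCl)cc1` gives 35000 nM in a functional assay on M21 cells (Homo sapiens) for antiproliferative activity, with a stated time of 48 h; on this read-out higher numbers stand for weaker inhibition and lower numbers for stronger inhibition.
Compound 2 `CCNC(=O)NCc1ccc(C(C)(C)C)cc1` gives > 100000 nM in this assay, which is a limit of the assay and not a number.

Compound 1 is the only one of the two with a measured number in this assay; the other value is a limit (the limit of > 100000 nM in this assay, at which 1 of the 2 values shown sits). Going by the values given here, no pair of measured compounds differing in a single place is available, so the size that one such change makes on cell growth has not been measured here.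

Compound 3 `CC(C)(C)c1ccc(NC(=O)CCl)cc1` has not yet been measured. It differs from compound 1 in one place: chloromethyl in place of (3-chloropropyl)amino on a carbonyl carbon. The urea of compound 1 is thereby turned into a shorter amide bearing a chloromethyl group on the carbonyl carbon. Among the compounds with values here, with no measured step to lean on, the expectation rests on the change itself; a step beyond the usual scatter, toward stronger inhibition, is expected, of size a 3.5-fold lower number from compound 1 to compound 3 (0.54 log units; beyond the scatter). Compound 3 is accordingly expected to give about 10000 nM in this assay, most likely between 2000 nM and 50000 nM.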

Compound 3, half-maximal inhibitory concentration: 5400 nM
For compound 3 the middle estimate is 1.9-fold (0.27 log units) above the measured one; the range from low to high includes it.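

Swapping (3-chloropropyl)amino for chloromethyl on the carbonyl carbon gives a 6.5-fold lower number from compound 1 to compound 3 (0.81 log units; beyond the scatter) in this assay, and this is the first size measured here for a single change. It shows that the group on this carbonyl carbon has a real, if modest, bearing on this read-out, and that the urea can give way to the shorter amide without any loss of inhibition of cell growth. No measurement shown bears on the reason for this step.

On these data alone, this one step changes several things at once: the chain gets shorter, and the nitrogen with its hydrogen goes, so the share of each remains open. A plain methyl group or a bromomethyl group in place of chloromethyl would test whether the chlorine matters, while a 2-chloroethyl group or a longer chloroalkyl chain on the same carbonyl carbon would show how the number follows chain length with no nitrogen in the chain.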